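Carbonyl substituent series in the growth assay: compound 4

The source may hold more compounds than are shown below. What is called first, only, known or untested is meant among the compounds shown, and "the series" means these compounds.

Three measured compounds share one core and differ only in the group on the carbonyl carbon. Compound 1 `CNC(=O)c1sc(-c2ccc(Cl)cc2)nc1C(Br)Br` gives 74600 nM in an ADME assay on BHK15 cells (Mesocricetus auratus) for inhibition, read by XTT assay, with a stated time of 36 h; a lower number here means a stronger inhibitor of growth, a higher number a weaker inhibitor of growth. Compound 2 `CCN(CC)C(=O)c1sc(-c2ccc(Cl)cc2)nc1C(Br)Br` gives 63500 nM in this assay, and compound 3 `CCSC(=O)c1sc(-c2ccc(Cl)cc2)nc1C(Br)Br` gives 81400 nM. Compound 2 has the lowest of the three numbers, yet every step among them lies within the scatter: a 1.2-fold lower number from compound 1 to compound 2 (0.07 log units; within the scatter), a 1.1-fold higher number from compound 1 to compound 3 (0.04 log units; within the scatter) and a 1.3-fold higher number from compound 2 to compound 3 (0.11 log units; within the scatter). Compound 4 `O=C(NC[C@@H](O)CO)c1sc(-c2ccc(Cl)cc2)nc1C(Br)Br` is not yet measured. It differs from compound 2 by (2,3-dihydroxypropyl)amino in place of diethylamino on a carbonyl carbon. Going by the values given here, the three measured steps all concern the same place and all stayed within the scatter, so a further exchange on the carbonyl carbon is expected to produce no step in this assay beyond the scatter, in either direction. The step from compound 2 to compound 4 is therefore estimated as a 1.1-fold higher number from compound 2 to compound 4 (0.04 log units; within the scatter). Compound 4 is accordingly expected to give about 70000 nM, with a range from 35000 nM to 140000 nM.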

Compound 4, concentration for 50% growth inhibition: 158000 nM
For compound 4 the middle estimate is 2.3-fold (0.35 log units) below the measured one; measured number above the stated range.
By their numbers in this assay, from the lowest: compounds 2, 1, 3 and 4 (each within the scatter of the next, the first and the last beyond it).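

Going by these compounds alone, in working terms, the carbonyl carbon is no longer a silent position in this assay: replacing diethylamino with (2,3-dihydroxypropyl)amino gives the first steps here to lie beyond the scatter, modest in size (a 2.5-fold higher number from compound 2 to compound 4 (0.40 log units; beyond the scatter)) and (a 2.1-fold higher number from compound 1 to compound 4 (0.33 log units; beyond the scatter)). The separation is incomplete, since the step from the thioester stays within the scatter (a 1.9-fold higher number from compound 3 to compound 4 (0.29 log units; within the scatter)), so compound 4 stands apart from compound 1 and compound 2 but not from compound 3. Nothing measured here accounts for this shift.

Still open, going by these compounds, is whether a simpler 2-hydroxyethylamino group would give a comparable step or whether the full (2,3-dihydroxypropyl)amino group is needed. On these data alone, the effect of the opposite stereocentre in that group, and the behaviour of a carboxylic acid or a basic amine on the same chain, also remain open.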